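From methyl to butyl on compound 2

The source may report more compounds than this note shows. Statements on the series, on what has been measured and on what is new or still open speak of the compounds shown alone.

In a functional assay on HT-29 cells (Homo sapiens) for antiproliferative activity, read by sulforhodamine B assay, with a stated time of 48 h (a higher number here means a weaker inhibitor, a lower number a stronger inhibitor), compound 1 `Cc1ccccc1OS(=O)(=O)c1ccc(N2CCN(C)C2=O)cc1` gives 4800 nM, compound 3 `CN1CCN(c2ccc(S(=O)(=O)Oc3ccc(Cl)cc3)cc2)C1=O` gives 12000 nM, and compound 2 `COc1ccccc1OS(=O)(=O)c1ccc(N2CCN(C)C2=O)cc1` gives 26000 nM, the highest number of the three. Compound 4 `CCCCN1CCN(c2ccc(S(=O)(=O)Oc3ccccc3OC)cc2)C1=O` carries butyl where compound 2 carries methyl: propyl in place of hydrogen on a saturated chain carbon bound to an amide-type nitrogen in a ring. Within the data shown here, no measured step touches this place. The three available steps change only the group on the sulfonate oxygen: a 5.4-fold higher number from compound 1 to compound 2 (0.73 log units; beyond the scatter), a 2.5-fold higher number from compound 1 to compound 3 (0.40 log units; beyond the scatter) and a 2.2-fold lower number from compound 2 to compound 3 (0.34 log units; beyond the scatter), all modest. They bear on the new change only as a guide to size. A modest move to a lower number is expected, resting on compound 2 standing highest at 26000 nM, though the direction is uncertain. The expected step is a 2.2-fold lower number from compound 2 to compound 4 (0.34 log units; beyond the scatter). For compound 4 the estimate is 12000 nM, with an expected range of 3000 nM to 45000 nM.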

Compound 4, half-maximal inhibitory concentration: > 100000 nM
Compound 4 ended at the assay's limit; the forecaster's own chance of this, stated with the estimate: 10%; at least 8.3-fold (0.92 log units) between middle value and limit.
By their numbers in this assay, from the lowest: compound 1; then compound 3; then compound 2. At a limit, above all of these: compound 4.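

In this assay compound 4 stands at > 100000 nM, a limit of the assay and not a number. Methyl to butyl on the saturated chain carbon bound to an amide-type nitrogen in a ring gives an at least 3.8-fold higher number from compound 2 to compound 4 (0.58 log units; beyond the scatter), so this place, untouched by the earlier steps, does affect the reading, and lengthening the chain here moves it upward. Only the minimum size of that step can be read: the limit of > 100000 nM in this assay, at which 1 of the 4 values shown sits.

From the compounds shown here alone, whether ethyl or propyl at this place, or an amine or carboxylic acid on the chain, would give a measurable value remains open. Also open, going by these compounds, is whether butyl acts the same way alongside the 2-methylphenyl group of compound 1 or the 4-chlorophenyl group of compound 3.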